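Swapping an ortho methoxy for trifluoromethyl on the ester ring

The source may hold more compounds than are shown below. What is called first, only, known or untested is meant among the compounds shown, and "the series" means these compounds.

Measured compounds:
Compound 1, `COc1ccccc1C(=O)OC1CCN(C)CC1`, gives 1.43.
Compound 2, `CN1CCC(OC(=O)c2ccc(Cl)cc2)CC1`, gives 1.11.
Compound 3, `COc1cccc(OC)c1C(=O)OC1CCN(C)CC1`, gives 0.63.

All three share a core in which a basic ring bearing a methyl group is joined through an ester to a benzene ring; they differ only in what sits on that benzene ring. The numbers come from a functional assay on the whole organism with Mus musculus as the target; on this read-out lower numbers stand for lower potency and higher numbers for higher potency (the scale is a negative logarithm). On this read-out compound 1 stands highest of the three: compound 2 lies a little lower, beyond the scatter, and compound 3 lies lowest. Going by the values given here, the one single-point step among the measured compounds is a number 0.80 log units lower from compound 1 to compound 3 (beyond the scatter), so adding a second methoxy to the ring costs potency.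

Compound 4, `CN1CCC(OC(=O)c2ccccc2C(F)(F)F)CC1`, has not been measured. It differs from compound 1 in one place: trifluoromethyl in place of methoxy on an aromatic carbon. Among the compounds with values here, no measured pair shows a trifluoromethyl, and no measured pair removes a methoxy alone, so the step to compound 4 has no direct precedent. Within the data shown here, the only guidance is that every change away from compound 1 so far has lowered the number, and that compound 2, which carries a halogen instead of a methoxy, sits below compound 1. A modest fall is therefore expected, with wide uncertainty: the estimated step is a number 0.33 log units lower from compound 1 to compound 4 (beyond the scatter). Compound 4 is expected to give about 1.1, most likely between 0.6 and 1.6.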

Compound 4, logarithm of the reciprocal of the active concentration, log(1/C): 1.49
The estimate for compound 4 lay 0.39 log units below the measured number, within the range that was stated.
By their numbers in this assay, from the lowest: compound 3; then compound 2; then compounds 1 and 4 (each within the scatter of the next).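

In this assay, trifluoromethyl in place of methoxy on an aromatic carbon ortho to a large group gives a number 0.06 log units higher from compound 1 to compound 4 (within the scatter), so the two groups cannot be told apart on this read-out. Going by these compounds alone, the only earlier step between measured compounds, a number 0.80 log units lower from compound 1 to compound 3 (beyond the scatter), lowered the number, whereas this one shows that the methoxy of compound 1, with its 1 hydrogen-bond acceptor, can be replaced at this place without a measurable fall by a group with 0 hydrogen-bond acceptors and 4 heavy atoms instead of 2. Nothing available explains why these two different groups give matching numbers here.

The compounds shown leave open whether the number would hold with a fluorine or a plain hydrogen at this place, or with a group of another kind, such as an amine, a carboxylic acid or a longer chain like butoxy. They also leave open whether trifluoromethyl would match methoxy at other places on the same aromatic ring, where the chloro group of compound 2 and the second methoxy of compound 3 offer no direct comparison.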